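This account rests on a few compounds, and the source may have more. Where it says the series, first, only, none or still open, it means among the compounds named here.

Measured so far:
compound 1, `NC(=O)CN1CCN(c2nc(-c3ccccn3)nc3c2CN(Cc2ccccc2)CC3)CC1`: 207000 nM
compound 2, `CN1CCN(CCCNc2nc(-c3ccccn3)nc3c2CN(Cc2ccccc2)CC3)CC1`: 180000 nM
compound 3, `NC(=O)CN1CCN(c2nc(-c3cccnc3)nc3c2CN(Cc2ccccc2)CC3)CC1`: 156000 nM

All three were measured in a physicochemical assay for solubility, read by HPLC, with a stated time of 24 h, at pH 7.4, tested at 250 uM; a lower number here means a less soluble compound, a higher number a more soluble compound. Compound 1 and compound 2 differ at one place: (3-(4-methylpiperazin-1-yl)propyl)amino in place of 4-(carbamoylmethyl)piperazin-1-yl on an aromatic carbon The step is a 1.2-fold lower number from compound 1 to compound 2 (0.06 log units; within the scatter). Compound 1 and compound 3 differ in their cores: pyridin-3-yl in place of pyridin-2-yl on an aromatic carbon That step is a 1.3-fold lower number from compound 1 to compound 3 (0.12 log units; within the scatter).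

Compound 4, `CN1CCN(CCCNc2nc(-c3cccnc3)nc3c2CN(Cc2ccccc2)CC3)CC1`, is not yet measured. It differs from compound 3 by the same kind of change seen from compound 1 to compound 2: (3-(4-methylpiperazin-1-yl)propyl)amino in place of 4-(carbamoylmethyl)piperazin-1-yl on an aromatic carbon Around the place, the only difference in the description is that the carbon is meta to a pyridin-3-yl group in compound 3 and meta to a pyridin-2-yl group in compound 1.

On that basis, a step of about the same size as a 1.2-fold lower number from compound 1 to compound 2 (0.06 log units; within the scatter) is expected, so the estimated step from compound 3 to compound 4 is a 1.2-fold lower number from compound 3 to compound 4 (0.06 log units; within the scatter). Compound 4 is therefore estimated to give 135000 nM in this assay, with a likely range from 75000 nM to 240000 nM.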

Compound 4, solubility: 234000 nM
Estimate against measurement, compound 4: 1.7-fold (0.24 log units) below, within the range that was stated.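

In this assay, replacing 4-(carbamoylmethyl)piperazin-1-yl with (3-(4-methylpiperazin-1-yl)propyl)amino gives a 1.5-fold higher number from compound 3 to compound 4 (0.18 log units; within the scatter) with pyridin-3-yl in place and a 1.2-fold lower number from compound 1 to compound 2 (0.06 log units; within the scatter) with pyridin-2-yl, so on this pair of cores the change carries across without a step beyond the scatter. The pyridine change, seen with the other side chain, gives a 1.3-fold higher number from compound 2 to compound 4 (0.11 log units; within the scatter) and so also stays within the scatter. This does not show that either change has a real effect or a direction on either core, and no measurement given here offers an explanation.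

The compounds shown leave open whether a carboxylic acid in place of the primary amide, or a morpholine in place of the piperazine, would give a step beyond the scatter. They also leave open what a longer chain than propyl, or a phenyl in place of the pyridine, would do.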